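This account rests on a few compounds, and the source may have more. Where it says the series, first, only, none or still open, it means among the compounds named here.

Measured compounds:
- compound 1, `CNC(=O)c1ccc(Oc2cccc(NC(=S)Nc3ccc(F)cc3)c2)nc1`: 21700 nM
- compound 2, `CNC(=O)c1ccc(Oc2cccc(NC(=S)Nc3ccc(OC(F)(F)F)cc3)c2)nc1`: 56000 nM
- compound 3, `CNC(=O)c1ccc(Oc2cccc(NC(=S)Nc3ccc(F)c(C(F)(F)F)c3)c2)nc1`: 13300 nM

All three share one core and differ only in the substituents on the phenyl ring that sits on the thiourea nitrogen. In a functional assay on MDA-MB-231 cells (Homo sapiens) for antiproliferative activity, read by MTT assay (on this read-out higher numbers stand for weaker inhibition and lower numbers for stronger inhibition), compound 1 gives 21700 nM, the second highest of the three numbers. Compound 3 is the nearest to it, and the gap between them, a 1.6-fold lower number from compound 1 to compound 3 (0.21 log units; within the scatter), is within the scatter, so nothing separates the two. Compound 2 is the furthest, with a 2.6-fold higher number from compound 1 to compound 2 (0.41 log units; beyond the scatter), a modest loss.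

Compound 4, `CNC(=O)c1ccc(Oc2cccc(NC(=S)Nc3ccc(Cl)cc3Cl)c2)nc1`, has not yet been measured. Its change from compound 1 is 2,4-dichlorophenyl in place of 4-fluorophenyl on an amide-type nitrogen. For the measured compounds named here, no measured pair makes exactly this change. The two known steps show that altering this phenyl ring can push the number either way: trifluoromethoxy in place of fluoro gave a 2.6-fold higher number from compound 1 to compound 2 (0.41 log units; beyond the scatter), while trifluoromethyl in place of hydrogen gave a 1.6-fold lower number from compound 1 to compound 3 (0.21 log units; within the scatter). With one halogen swapped for another and a second chlorine added, the nearest guidance is the small step of compound 3, so the step of a 1.4-fold lower number from compound 1 to compound 4 (0.16 log units; within the scatter) is expected to stay near the scatter, if anything toward a slightly lower number.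

Compound 4 is therefore estimated at 15000 nM, within a range from 6000 nM to 40000 nM.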

Compound 4, half-maximal inhibitory concentration: 20700 nM
For compound 4 the middle estimate is 1.4-fold (0.14 log units) below the measured one, within the range that was stated.
By their numbers in this assay, from the lowest: compounds 3, 4 and 1 (each within the scatter of the next); then compound 2.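

In this assay, 2,4-dichlorophenyl in place of 4-fluorophenyl on the amide-type nitrogen gives a 1.0-fold lower number from compound 1 to compound 4 (0.02 log units; within the scatter) and so leaves compound 1 and compound 4 indistinguishable, which shows that this position can carry a ring with two chlorines and lose nothing that this read-out can detect. Among the changes to this ring so far, only trifluoromethoxy stands out, with a 2.6-fold higher number from compound 1 to compound 2 (0.41 log units; beyond the scatter) as the one step beyond the scatter, while a 1.6-fold lower number from compound 1 to compound 3 (0.21 log units; within the scatter) lies within it, as does the new step. Nothing available explains why the swap to two chlorines leaves the number within the scatter.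

This single step swaps the halogen and adds a second one at the same time, so the separate contribution of each change cannot be read from it. Also open, as far as these compounds go, is how the number would respond to quite different groups on this ring, such as an amine or a carboxylic acid, or to a simple butyl chain in place of the whole ring on the amide-type nitrogen.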